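Compound 2 and a Carboxy Group Added on the Ring Nitrogen

The source may hold more compounds than are shown below. What is called first, only, known or untested is meant among the compounds shown, and "the series" means these compounds.

Of the compounds shown here, three sharing one core have been measured in a functional assay on a cell-free system (plasma) for inhibition of platelet-activating factor acetylhydrolase (Homo sapiens), tested at 100 nM; on this read-out lower numbers stand for less inhibition and higher numbers for more inhibition at the one concentration tested (going by the name of the read-out). Compound 1 `CCCCCCCCN(C)C(=O)Cn1cc(Cc2cnc(OC)nc2)c(=O)nc1SCc1ccc(F)cc1` gives 39%, compound 2 `CCCCCCCCN(C)C(=O)Cn1cc(Cc2cnc(=O)n(C)c2)c(=O)nc1SCc1ccc(F)cc1` gives 55%, and compound 3 `CCCCCCCCCCCCN(C)C(=O)Cn1cc(Cc2cnc(=O)n(C)c2)c(=O)nc1SCc1ccc(F)cc1` gives 75%. Compound 2 thus stands in the middle of the three, with a number 16 percentage points higher from compound 1 to compound 2 (beyond the scatter) and a number 20 percentage points higher from compound 2 to compound 3 (beyond the scatter) both beyond the scatter. Compound 4 `CCCCCCCCN(C)C(=O)Cn1cc(Cc2cnc(=O)n(CC(=O)O)c2)c(=O)nc1SCc1ccc(F)cc1` is not yet measured; it differs from compound 2 by carboxy in place of hydrogen on a saturated chain carbon bound to an aromatic nitrogen. Within the data shown here, no measured step alters this position, and the nearest one, a number 16 percentage points higher from compound 1 to compound 2 (beyond the scatter), replaces the whole ring that carries the methyl. Among the measured compounds shown here, with no step at this place to lean on, no change beyond the scatter is expected, giving a number 5 percentage points lower from compound 2 to compound 4 (within the scatter). Compound 4 is therefore estimated at 50%, ranging from 30% to 70%.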

Compound 4, a percentage reported as inhibition, at one concentration (the size of the read-out at that concentration, not a potency): 56%
Beside the measured number, compound 4's estimate is 6 percentage points below it; low and high end bracket the measured number.
By their numbers in this assay, from the lowest: compound 1; then compounds 2 and 4 (each within the scatter of the next); then compound 3.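

In this assay the change from methyl to carboxymethyl gives a number 1 percentage points higher from compound 2 to compound 4 (within the scatter) at this saturated chain carbon bound to an aromatic nitrogen, so the position takes a carboxy with no change that stands out from the scatter. Replacing the whole ring group gives a number 17 percentage points higher from compound 1 to compound 4 (beyond the scatter) even with the carboxy present. As far as these compounds go, how an amine or a methyl ester would read on this carbon stays open, as does the carboxy combined with the longer chain of compound 3. No measurement offered here explains this result.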